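The source may hold more compounds than are shown below. What is called first, only, known or untested is meant among the compounds shown, and "the series" means these compounds.

Compound 1 `O=C1C=CC[C@@H]([C@H]2C[C@@H]2c2ccccc2)O1`: 34900 nM
Compound 2 `COc1ccc(/C=C/[C@H]2CC=CC(=O)O2)cc1`: > 100000 nM (a limit)
Compound 3 `COc1ccc(/C=C/[C@@H]2CC=CC(=O)O2)cc1`: > 100000 nM (a limit)

In a functional assay on HBL-100 cells (Homo sapiens) for antiproliferative activity, read by luminescence and CellTiter-Glo, with a stated time of 48 h (on this read-out higher numbers stand for weaker inhibition and lower numbers for stronger inhibition), compound 2 gives > 100000 nM, which is a limit of the assay and not a number. Compound 2 thus stands at the limit of > 100000 nM in this assay, at which 2 of the 3 values shown sit. For the measured compounds named here, the only measured step between close relatives is a step that the two limits leave unreadable from compound 2 to compound 3, and it concerns (the fact that compounds 2 and 3 differ only in the configuration as drawn), so it gives no size to carry over.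

Compound 4 `O=C1C=CC[C@H](/C=C/c2ccc(F)cc2)O1` differs from compound 2 in one place: fluoro in place of methoxy on an aromatic carbon. Going by the values given here, no measured step covers fluoro in place of methoxy, so its size cannot be read from the data. Among the compounds with values here, the only true number in this assay comes from compound 1 at 34900 nM, and this suggests that values within the measurable range are possible in this small set. A modest move towards stronger inhibition is therefore expected, though compound 4 could also end at the limit. The expected change is an at least 1.6-fold lower number from compound 2 to compound 4 (0.22 log units; that floor lies within the scatter). For compound 4 the estimated value is 60000 nM, with an expected range of 20000 nM to 150000 nM.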

Compound 4, half-maximal inhibitory concentration: 14100 nM
Beside the measured number, compound 4's estimate is 4.3-fold (0.63 log units) above it, and the stated range ends above it.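

In this assay, for the compounds shown here, this is the first change between close relatives whose effect can be read: fluoro in place of methoxy on the aromatic carbon gives an at least 7.0-fold lower number from compound 2 to compound 4 (0.85 log units; beyond the scatter) at this position. Compound 2 gives > 100000 nM here, which is a limit and not a number. The true change may be larger, and the step is only a floor because of where compound 2 sits: the limit of > 100000 nM in this assay, at which 2 of the 4 values shown sit.

The compounds shown do not tell whether fluoro itself matters or whether losing methoxy is enough, and a plain hydrogen, a chloro or an amine at this position would help separate the two. From the compounds shown here alone, the step between the two mirror-drawn limit compounds cannot be read, so the effect of the configuration at the saturated ring carbon also stays open.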